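This account rests on a few compounds, and the source may have more. Where it says the series, first, only, none or still open, it means among the compounds named here.

Going by the values given here, in an assay for inhibition of Maternal embryonic leucine zipper kinase (Homo sapiens), read by ADP-Glo, with a stated time of 0.5 h (a lower number here means a stronger inhibitor, a higher number a weaker inhibitor), compound 3 `CCNc1sc(C(=O)c2ccc(Cl)s2)c(N)c1C#N` gives 222 nM, the lowest of the three numbers known so far. Among the compounds with values here, compound 1 `CC(C)Nc1sc(C(=O)c2ccco2)c(N)c1C#N` gives 1350 nM and compound 2 `CC(C)Nc1sc(C(=O)c2cc(Br)cs2)c(N)c1C#N` gives 599 nM; the single step between measured compounds, a 2.3-fold lower number from compound 1 to compound 2 (0.35 log units; beyond the scatter), concerns the group on the carbonyl carbon and leaves the amine untouched. Compound 4 `N#Cc1c(Nc2ccccc2F)sc(C(=O)c2ccc(Cl)s2)c1N` differs from compound 3 by 2-fluorophenyl in place of ethyl on a nitrogen on an aromatic ring. Within the data shown here, no measured pair alters the substituent on that nitrogen, so none of the known steps bears on this change, and the expectation is a shift that stays within the usual scatter, in either direction. Compound 4 is therefore estimated at 220 nM, with a range from 60 nM to 800 nM, which amounts to an expected step of a 1.0-fold lower number from compound 3 to compound 4 (0.00 log units; within the scatter).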

Compound 4, half-maximal inhibitory concentration: 707 nM
Compound 4: the middle estimate sits 3.2-fold (0.51 log units) below what was measured; measured number inside the range.
By their numbers in this assay, from the lowest: compound 3; then compounds 2, 4 and 1 (each within the scatter of the next, the first and the last beyond it).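

Going by these compounds alone, this is the first measured change at the nitrogen on an aromatic ring, and in this assay the substituent there matters: 2-fluorophenyl in place of ethyl gives a 3.2-fold higher number from compound 3 to compound 4 (0.50 log units; beyond the scatter) with the rest of the molecule unchanged. The step is modest, so a ring on this nitrogen is compatible with inhibition in this series, though at some cost relative to ethyl. No evidence at hand accounts for the step.

Going by these compounds, it remains open how phenyl without the fluorine, benzyl or a longer chain such as butyl would fare on this nitrogen. Also open, on these data alone, is whether the same step would hold with furan-2-yl or 4-bromothiophen-2-yl on the carbonyl carbon.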